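Swapping the urea end group in a sulfonamide series

The source may hold more compounds than are shown below. What is called first, only, known or untested is meant among the compounds shown, and "the series" means these compounds.

Of the compounds shown here, two sharing one core have been measured in a functional assay on MDA-MB-231 cells (Homo sapiens) for antiproliferative activity, read by MTT assay, with a stated time of 72 h; a lower number here means a stronger inhibitor, a higher number a weaker inhibitor. Compound 1 `CC(=O)Nc1ccc(S(=O)(=O)Nc2cccc(-c3nc(-c4ccc(NC(=O)c5cccnc5)cc4Cl)no3)c2)cc1` gives 2500 nM. Compound 2 `CCN(CC)C(=O)Nc1ccc(S(=O)(=O)Nc2cccc(-c3nc(-c4ccc(NC(=O)c5cccnc5)cc4Cl)no3)c2)cc1` gives 8700 nM. For the measured compounds named here, compound 2 therefore stands with the highest number of the two, its only neighbour being compound 1, and the step of a 3.5-fold higher number from compound 1 to compound 2 (0.54 log units; beyond the scatter) carried a diethylamino in place of methyl on a carbonyl carbon.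

The next compound, compound 3 `O=C(Nc1ccc(S(=O)(=O)Nc2cccc(-c3nc(-c4ccc(NC(=O)c5cccnc5)cc4Cl)no3)c2)cc1)NC1CCCC1`, changes that same end once more: cyclopentylamino in place of diethylamino on a carbonyl carbon, so the diethylcarbamoyl becomes a cyclopentylcarbamoyl, bringing one five-membered non-aromatic ring of carbon only and one hydrogen-bond donor.

Going by the values given here, only one measured step touches this position, and it does not replace one amino group by another, so it bears on the new change only loosely. It shows that this end of the molecule can shift the number by a modest amount. With no closer guide, the expected step of a 1.6-fold lower number from compound 2 to compound 3 (0.20 log units; within the scatter) is small and the direction uncertain, leaning toward a somewhat lower number. Compound 3 is thus estimated at 5500 nM in this assay, within a range from 1500 nM to 20000 nM.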

Compound 3, half-maximal inhibitory concentration: > 10000 nM
Compound 3 gave a limit, no number; the forecaster's own chance of this, stated with the estimate: 10%; middle value at least 1.8-fold (0.25 log units) from the limit.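

Compound 3 gave a limit of the assay, not a number: the limit of > 10000 nM in this assay, at which 1 of the 3 values shown sits. Measured against methyl, the cyclopentylamino group brings an at least 4.0-fold higher number from compound 1 to compound 3 (0.60 log units; beyond the scatter), which stands alongside the earlier 3.5-fold higher number from compound 1 to compound 2 (0.54 log units; beyond the scatter), so two different amino groups at this place now both give a higher number than methyl. Cyclopentylamino in place of diethylamino brings an at least 1.1-fold higher number from compound 2 to compound 3 (0.06 log units; that floor lies within the scatter); that floor does not separate the two amino groups, but the added ring and hydrogen-bond donor did not bring the number down.

From the compounds shown here alone, how far the true number of compound 3 lies past its limit stays unknown, so the real size of its step from compound 2 remains open. Also open, going by these compounds, is whether a smaller group on the same carbonyl carbon, such as a plain amine or methylamino, or a ring holding oxygen, such as morpholine, would bring the number back toward compound 1 at 2500 nM.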